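Quinoline series: chloro replacing the aminoalkyl side chain

The compounds below may be only part of what the source reports. "The series", "measured", "known", "first", "only" and "open" are said of these compounds alone.

Compound 3 `C=CCOc1ccc2c(NCCN(C)C)ccnc2c1` gives 1560 nM in a functional assay on SK-OV-3 cells (Homo sapiens) for cytotoxicity, read by MTT assay, with a stated time of 48 h; on this read-out lower numbers stand for stronger inhibition and higher numbers for weaker inhibition; that is the lowest of the three numbers recorded, with compound 2 `CC(C)Oc1ccc2c(Cl)ccnc2c1` at 3060 nM within the scatter of it and compound 1 `CCOc1ccc2c(Cl)ccnc2c1` at 3460 nM beyond it. Within the data shown here, the only single-point step measured so far, a 1.1-fold lower number from compound 1 to compound 2 (0.05 log units; within the scatter), concerns the alkoxy chain and not the position changed here, so it does not bear on the present step. Compound 4 `C=CCOc1ccc2c(Cl)ccnc2c1` is compound 3 with chloro in place of (2-(dimethylamino)ethyl)amino on an aromatic carbon. Compounds 1 and 2 both carry chloro at that place and both differ from compound 3 in the alkoxy group as well, so their values can only be read as the range the chloro-bearing compounds occupy in this assay. On that basis compound 4 is expected to sit with compounds 1 and 2 rather than with compound 3, a step of a 1.9-fold higher number from compound 3 to compound 4 (0.28 log units; within the scatter) to weaker inhibition. The estimate for compound 4 in this assay is 3000 nM, with a range from 1200 nM to 7500 nM.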

Compound 4, half-maximal inhibitory concentration: 4030 nM
Compound 4: the middle estimate sits 1.3-fold (0.13 log units) below what was measured; the range from low to high includes it.
By their numbers in this assay, from the lowest: compounds 3, 2, 1 and 4 (each within the scatter of the next, the first and the last beyond it).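

In this assay, among these compounds, chloro in place of (2-(dimethylamino)ethyl)amino on the aromatic carbon opposite the ring nitrogen is the first change at this position read with the allyl ether held constant, and it gives a 2.6-fold higher number from compound 3 to compound 4 (0.41 log units; beyond the scatter). With chloro held constant, allyl in place of isopropyl gives a 1.3-fold higher number from compound 2 to compound 4 (0.12 log units; within the scatter), and vinyl in place of methyl on the saturated chain carbon gives a 1.2-fold higher number from compound 1 to compound 4 (0.07 log units; within the scatter). Compound 1, compound 2 and compound 4 therefore lie within the scatter of one another, and among the single-place changes read so far only the loss of the side chain goes beyond it.

Nothing at hand accounts for the size of this step. From the compounds shown here alone, whether a longer chain, a piperidine or a primary amine at this place would give a similar number remains open.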